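This account rests on a few compounds, and the source may have more. Where it says the series, first, only, none or still open, it means among the compounds named here.

Among the compounds with values here, compound 1 `COC(=O)C#CC(O/C=C/C(=O)OC)C1CC1` is the methyl-ester member of the series; in a functional assay on SW1573 cells (Homo sapiens) for antiproliferative activity, read by sulforhodamine B assay, with a stated time of 48 h (on this read-out higher numbers stand for weaker inhibition of growth and lower numbers for stronger inhibition of growth), compound 1 gives 1800 nM, the lowest of the two numbers so far. Compound 2 `CC(C)C(C#CC(=O)OC(C)(C)C)O/C=C/C(=O)OC(C)(C)C` gives 4800 nM, a higher number that sits beyond the scatter. Compound 3 `CCC(C)C(C#CC(=O)OC)O/C=C/C(=O)OC` has not been measured; it differs from compound 1 by sec-butyl in place of cyclopropyl on a saturated chain carbon bound to an oxygen on an unsaturated carbon and a triple-bonded carbon. Within the data shown here, with no step between measured compounds to lean on, only a small move toward a higher number is expected, a 1.4-fold higher number from compound 1 to compound 3 (0.14 log units; within the scatter), not clearly beyond the scatter. Compound 3 is therefore estimated at 2500 nM, within 900 nM to 7000 nM.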

Compound 3, concentration for 50% growth inhibition: 910 nM
Beside the measured number, compound 3's estimate is 2.7-fold (0.44 log units) above it; the range from low to high includes it.
By their numbers in this assay, from the lowest: compounds 3 and 1 (each within the scatter of the next); then compound 2.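

In this assay, sec-butyl in place of cyclopropyl on this saturated chain carbon gives a 2.0-fold lower number from compound 1 to compound 3 (0.30 log units; within the scatter), so the three-membered ring is not needed to hold the level of compound 1. An open branched chain with one more carbon is accepted at this position without a change beyond the scatter. Nothing available gives a reason for this result. As far as these compounds go, whether an amine or a longer chain would be accepted at the same position remains open. Also open, from the compounds shown here alone, is how a carboxylic acid in place of a methyl ester would read.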